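Swapping a methylphenyl for a pyridyl ring

The compounds below may be only part of what the source reports. "The series", "measured", "known", "first", "only" and "open" are said of these compounds alone.

Compound 3 `Cc1ccc(OCc2cc3n(n2)CCN(c2ccc(F)cc2)C3=O)cc1` gives 58% in a functional assay on HEK293 cells for positive allosteric modulation of metabotropic glutamate receptor 5 (Homo sapiens), read by calcium flux (a higher number here means a larger maximal response, a lower number a smaller maximal response), the lowest of the three measured values. Compound 2 `O=C1c2cc(COc3ccccc3F)nn2CCN1c1ccc(F)cc1` gives 66%, and compound 1 `O=C1c2cc(COc3ccccc3)nn2CCN1c1ccc(F)cc1` gives 79%. The gap a number 8 percentage points lower from compound 2 to compound 3 (within the scatter) lies within the scatter, whereas a number 21 percentage points lower from compound 1 to compound 3 (beyond the scatter) is beyond it, as is a number 13 percentage points lower from compound 1 to compound 2 (beyond the scatter). Compound 4 `O=C1c2cc(COc3cccnc3)nn2CCN1c1ccc(F)cc1` is not yet measured; its change from compound 3 is pyridin-3-yl in place of 4-methylphenyl on an oxygen on a saturated carbon. Two parts of this change can be weighed. Taking the methyl away reverses the step seen in a number 21 percentage points lower from compound 1 to compound 3 (beyond the scatter), which points to a return toward the value of compound 1. Bringing a nitrogen into the six-membered ring has no measured counterpart among these compounds, so its effect is unknown and widens the range. Compound 4 is therefore expected to give 75%, between 55% and 95%, an estimated change of a number 17 percentage points higher from compound 3 to compound 4 (beyond the scatter).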

Compound 4, largest response reached (Emax), in percent of the reference or control that the assay uses: 69%
Compound 4: the middle estimate sits 6 percentage points above what was measured; low and high end bracket the measured number.
By their numbers in this assay, from the lowest: compounds 3, 2, 4 and 1 (each within the scatter of the next, the first and the last beyond it).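

Pyridin-3-yl in place of 4-methylphenyl gives a clear gain (a number 11 percentage points higher from compound 3 to compound 4 (beyond the scatter)), and this is the first ring at this place to carry a nitrogen. Measured against the ring without that nitrogen, the change is small (a number 10 percentage points lower from compound 1 to compound 4 (within the scatter)), and the 2-fluorophenyl compound gives a similarly close reading (a number 3 percentage points higher from compound 2 to compound 4 (within the scatter)), so in this assay a ring nitrogen on this oxygen costs no response that can be told from scatter. Nothing measured here explains these steps.

The compounds shown leave open whether the nitrogen's place in the ring matters, as pyridin-2-yl and pyridin-4-yl rings would show. They also leave open how the pyridin-3-yl ring responds to an added group, such as a methyl, an amine or a carboxylic acid.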